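Swapping the aryl on the hydrazone carbon of compound 3

The compounds below may be only part of what the source reports. "The series", "measured", "known", "first", "only" and "open" are said of these compounds alone.

Measured compounds:
compound 1 `COc1cc2c(Oc3ccc(NC(=O)N/N=C/c4ccc(C(F)(F)F)cc4)cc3F)ccnc2cc1OCCCN1CCCC1`: 1300 nM
compound 2 `COc1ccc(/C=N/NC(=O)Nc2ccc(Oc3ccnc4cc(OCCCN5CCCCC5)c(OC)cc34)c(F)c2)cc1`: 660 nM
compound 3 `COc1cc2c(Oc3ccc(NC(=O)N/N=C/c4ccc(C(F)(F)F)cc4)cc3F)ccnc2cc1OCCCN1CCCCC1`: 630 nM

All three were tested in a functional assay on MKN-45 cells (Homo sapiens) for cytotoxicity, read by MTT assay, with a stated time of 72 h; a higher number here means a weaker inhibitor, a lower number a stronger inhibitor. Compound 3 has the lowest number of the three, but compound 2 sits within the scatter of it, so the two cannot be ranked; only compound 1 is clearly apart, with a step of a 2.1-fold lower number from compound 1 to compound 3 (0.31 log units; beyond the scatter), and that step concerns the saturated ring at the end of the chain, not the part of the molecule changed here.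

Compound 4 `COc1cc2c(Oc3ccc(NC(=O)N/N=C/c4ccc(F)cc4Cl)cc3F)ccnc2cc1OCCCN1CCCCC1` differs from compound 3 in one place: 2-chloro-4-fluorophenyl in place of 4-(trifluoromethyl)phenyl on a carbon with a double bond to nitrogen. Among the compounds with values here, the one measured step that touches this same aromatic ring is a 1.0-fold lower number from compound 2 to compound 3 (0.02 log units; within the scatter), a swap of one substituent on that ring that left the number essentially where it was. Within the data shown here, no measured step covers a chlorine or a second halogen on this ring, so there is nothing to argue for a large move in either direction.

The expectation for compound 4 is therefore a step of a 1.1-fold lower number from compound 3 to compound 4 (0.02 log units; within the scatter), not beyond the scatter, giving an estimated value of 600 nM with a range from 250 nM to 1500 nM.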

Compound 4, half-maximal inhibitory concentration: 270 nM
For compound 4 the middle estimate is 2.2-fold (0.35 log units) above the measured one, and the stated range covers the measured number.
By their numbers in this assay, from the lowest: compound 4; then compounds 3, 2 and 1 (each within the scatter of the next, the first and the last beyond it).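

In this assay, 2-chloro-4-fluorophenyl on the carbon with a double bond to nitrogen gives a 2.3-fold lower number from compound 3 to compound 4 (0.37 log units; beyond the scatter), and set against 4-methoxyphenyl at the same place it gives a 2.4-fold lower number from compound 2 to compound 4 (0.39 log units; beyond the scatter). The earlier exchange of methoxy for trifluoromethyl on this ring, a 1.0-fold lower number from compound 2 to compound 3 (0.02 log units; within the scatter), suggested that the number might not respond to changes here, but these modest steps show that the choice of aryl group at this position can move it beyond the usual scatter. Nothing available explains why this aryl group gives the lower number.

The new aryl group differs from the one it replaces in more than one way, so the compounds shown cannot say whether the chlorine, the fluorine or the loss of trifluoromethyl accounts for the step, and a 2-chlorophenyl or a 4-fluorophenyl group at the same place would begin to separate these. From the compounds shown here alone, it also remains open whether 2-chloro-4-fluorophenyl would give a similar step with pyrrolidin-1-yl in place of piperidin-1-yl at the end of the chain.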